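A few compounds are considered here, and "the series" means these few. Any claim that something is new, unique, unknown or untested is made for them only; others in the source may bear on it.

Measured compounds:
compound 1 `COc1cc(NC(=O)Nc2cc(Nc3ccc(OC)c(C)c3)ncn2)cc(OC)c1`, 48.3%
compound 2 `CC(C)(C)c1cccc(Nc2cc(NC(=O)Nc3c(Cl)cccc3Cl)ncn2)c1`, 37.3%
compound 3 `CC(C)(C)c1ccc(Nc2cc(NC(=O)Nc3c(Cl)cccc3Cl)ncn2)cc1`, 42.3%

In a functional assay on HCC827 cells (Homo sapiens) for inhibition, read by MTT assay, with a stated time of 48 h, tested at 10 uM (a lower number here means less inhibition, a higher number more inhibition at the concentration tested (going by the name of the read-out)), compound 1 gives the highest of the three numbers. Compound 3 lies within the scatter of it, so the two cannot be ordered. Compound 2 lies beyond the scatter, lower than compound 1. Compound 4 `COc1cc(NC(=O)Nc2cc(Nc3ccc(Br)cc3OC)ncn2)cc(OC)c1` has not yet been measured. It differs from compound 1 in one place: 4-bromo-2-methoxyphenyl in place of 4-methoxy-3-methylphenyl on a nitrogen on an aromatic ring. Going by the values given here, no measured pair shows this change, so nothing in the data tells how this assay responds to it. All three measured compounds sit within a narrow band. The expected step, a number 3.3 percentage points lower from compound 1 to compound 4 (within the scatter), is small and in no direction beyond the scatter. Compound 4 is therefore expected to give about 45%, between 25% and 65%.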

Compound 4, a percentage reported as inhibition, at one concentration (the size of the read-out at that concentration, not a potency): 57.7%
Compound 4: middle estimate off by 12.7 percentage points, on the low side; measured number inside the range.
By their numbers in this assay, from the lowest: compounds 2, 3, 1 and 4 (each within the scatter of the next, the first and the last beyond it).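

In this assay, the change to 4-bromo-2-methoxyphenyl on a nitrogen on an aromatic ring gives a number 9.4 percentage points higher from compound 1 to compound 4 (within the scatter), so the two compounds cannot be ordered. Going by these compounds alone, this is the first reading at this position: it accepts this bromine-bearing ring with no change beyond the scatter. Nothing available explains the result. The compounds shown do not separate the contribution of the bromine from that of the methoxy group within this change. They also leave open how this position would respond to an amine or a carboxylic acid on the ring.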